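The compounds below may be only part of what the source reports. "The series", "measured", "known", "first", "only" and "open" are said of these compounds alone.

Compound 1 `COC(=O)CC(=O)N1N=C(c2ccc(N3CCN(C)CC3)cc2)CC1c1ccc(N(C)C)cc1`: -0.4%
Compound 2 `CN1CCN(c2ccc(C3=NN(S(=O)(=O)c4ccc(Br)cc4)C(c4ccc(N(C)C)cc4)C3)cc2)CC1`: 23.7%
Compound 3 `COC(=O)CC(=O)N1N=C(c2ccc(-n3cncn3)cc2)CC1c1ccc(N(C)C)cc1`: 6.8%

All three were tested in a functional assay on MDA-MB-231 cells (Homo sapiens) for inhibition, read by sulforhodamine B assay, tested at 10 uM; on this read-out lower numbers stand for less inhibition and higher numbers for more inhibition at the one concentration tested (going by the name of the read-out). Compound 3 holds the second highest of the three numbers. Its nearest neighbour is compound 1, and the step of a number 7.2 percentage points higher from compound 1 to compound 3 (within the scatter) lies within the scatter, so the two cannot be ordered. Compound 2 stands further off, and its value 23.7% sits beyond the scatter above compound 3.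

Compound 4 `CN(C)c1ccc(C2CC(c3ccc(-n4cncn4)cc3)=NN2S(C)(=O)=O)cc1` is not yet measured. Its difference from compound 3 is methylsulfonyl in place of ((methoxycarbonyl)methyl)carbonyl on an amine nitrogen in a ring.

Among the measured compounds shown here, one measured step bears on this change. In a number 24.1 percentage points higher from compound 1 to compound 2 (beyond the scatter) the same ((methoxycarbonyl)methyl)carbonyl was exchanged for a sulfonyl group on the ring nitrogen, with (4-bromophenyl)sulfonyl entering, and the number rose beyond the scatter. The group entering in compound 4 is methylsulfonyl, also a sulfonyl but with far fewer heavy atoms, so a rise of the same kind, likely smaller, is expected in this assay.

The step of a number 12.2 percentage points higher from compound 3 to compound 4 (beyond the scatter) is therefore expected to be upward, possibly beyond the scatter. Compound 4 is estimated at 19% in this assay, with a range from 4% to 36%.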

Compound 4, a percentage reported as inhibition, at one concentration (the size of the read-out at that concentration, not a potency): 7.8%
For compound 4 the middle estimate is 11.2 percentage points above the measured one, and the stated range covers the measured number.
By their numbers in this assay, from the lowest: compounds 1, 3 and 4 (each within the scatter of the next); then compound 2.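

In this assay, placing methylsulfonyl where ((methoxycarbonyl)methyl)carbonyl stood on the amine nitrogen in the ring gives a number 1 percentage points higher from compound 3 to compound 4 (within the scatter), so the two compounds cannot be ordered. This shows that a sulfonyl group at this position does not bring a rise in every case: the one rise seen here, a number 24.1 percentage points higher from compound 1 to compound 2 (beyond the scatter), came with (4-bromophenyl)sulfonyl as the entering group and with 4-methylpiperazin-1-yl rather than 1H-1,2,4-triazol-1-yl on the aromatic carbon. Nothing available here accounts for the difference between these two steps.

The two steps differ in both the entering sulfonyl group and the group on the aromatic carbon, so the compounds shown leave open which of these separates them, a question that a pair carrying (4-bromophenyl)sulfonyl and 1H-1,2,4-triazol-1-yl together, or methylsulfonyl and 4-methylpiperazin-1-yl together, would address. They also leave open how an unsubstituted phenylsulfonyl, a longer chain such as butylsulfonyl, or a carboxylic acid in place of the methyl ester would behave at this ring nitrogen.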